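The source may report more compounds than this note shows. Statements on the series, on what has been measured and on what is new or still open speak of the compounds shown alone.

Compound 2, `CNC(=O)c1cc(Oc2ccc3nc(Nc4cccc(OC(F)(F)F)c4)ncc3c2)ccn1`, in a physicochemical assay for solubility, at pH 7 (on this read-out higher numbers stand for higher solubility and lower numbers for lower solubility), gives < 1000 nM, which is a limit of the assay rather than a number. Its only comparator, compound 1 `CNC(=O)c1cc(Oc2ccc3nc(Nc4cccc(C(C)(C)C)c4)ncc3c2)ccn1`, sits at a limit too: in this assay compound 1 gives < 1000 nM. Between them lies a step that the two limits leave unreadable from compound 1 to compound 2, so this single measured step reveals nothing about its size, as the limit of < 1000 nM in this assay, at which 2 of the 2 values shown sit, shows. Compound 3 `CNC(=O)c1cc(Oc2ccc3nc(Nc4ccc(Br)cc4)ncc3c2)ccn1` differs from compound 2 by 4-bromophenyl in place of 3-(trifluoromethoxy)phenyl on a nitrogen on an aromatic ring. Among the measured compounds shown here, no measured step bears on this change, and no movement beyond the scatter is expected. Compound 3 is therefore estimated at 500 nM, from 100 nM to 2000 nM, meaning an expected step that the limit leaves unreadable from compound 2 to compound 3.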

Compound 3, solubility: < 1000 nM
Compound 3 ended at the assay's limit (the forecaster's own chance of this, stated with the estimate: 70%); the middle value does not contradict the limit.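

Among the compounds shown here, no step among compound 1, compound 2 and compound 3 can be read, because all three sit at a limit of the assay rather than at a number: the limit of < 1000 nM in this assay, at which 3 of the 3 values shown sit. The compounds shown leave open where each true value lies and whether any of these group changes moves it.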